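The source may hold more compounds than are shown below. What is called first, only, known or untested is meant among the compounds shown, and "the series" means these compounds.

Working notes on the series. In a functional assay on MCF7 cells (Homo sapiens) for cytotoxicity, read by MTT assay, with a stated time of 72 h (on this read-out lower numbers stand for stronger inhibition and higher numbers for weaker inhibition), compound 2 `O=C1c2c[n+]([O-])c3ccccc3c2C(=O)c2c1c1ccccc1n2Cc1cn([C@@H]2C[C@H](O)[C@@H](CO)O2)nn1` stands lowest of the two numbers measured, at 110 nM. Among the measured compounds shown here, compound 1 `O=C1c2c[n+]([O-])c3ccccc3c2C(=O)c2c1c1ccccc1n2Cc1cn(C[C@@H](O)CO)nn1` gives 600 nM, and the only measured step, a 5.5-fold lower number from compound 1 to compound 2 (0.74 log units; beyond the scatter), came from the exchange of 2,3-dihydroxypropyl for 4-hydroxy-5-(hydroxymethyl)oxolan-2-yl on the aromatic nitrogen.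

Compound 3 `CC1(C)OC[C@@H](Cn2cc(Cn3c4c(c5ccccc53)C(=O)c3c[n+]([O-])c5ccccc5c3C4=O)nn2)O1` differs from compound 2 at the same aromatic nitrogen: (2,2-dimethyl-1,3-dioxolan-4-yl)methyl in place of 4-hydroxy-5-(hydroxymethyl)oxolan-2-yl on an aromatic nitrogen. For the measured compounds named here, the entering (2,2-dimethyl-1,3-dioxolan-4-yl)methyl group carries no hydrogen-bond donor, while the group it replaces carries two; the step from compound 1 to compound 2 was the single change in which a donor-bearing side chain was swapped for another, and nothing measured addresses a donor-free one. The move away from the oxolane is expected to cost rather than gain, so the expected step is a 4.1-fold higher number from compound 2 to compound 3 (0.61 log units; beyond the scatter), toward a higher number, with wide uncertainty. Compound 3 is therefore estimated at 450 nM, within 130 nM to 1600 nM.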

Compound 3, half-maximal inhibitory concentration: > 1000 nM
Compound 3: a limit, no number; the forecaster's own chance of this, stated with the estimate: 5%; at least 2.2-fold (0.34 log units) between middle value and limit.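

Compound 3 gives a limit and not a number in this assay: the limit of > 1000 nM in this assay, at which 1 of the 3 values shown sits. At this aromatic nitrogen, (2,2-dimethyl-1,3-dioxolan-4-yl)methyl in place of 4-hydroxy-5-(hydroxymethyl)oxolan-2-yl gives an at least 9.0-fold higher number from compound 2 to compound 3 (0.95 log units; beyond the scatter), so a swap with no change in heavy-atom count, but with no hydrogen-bond donors in the entering group, does not keep the low number of compound 2. Against the open chain of compound 1 the step is an at least 1.6-fold higher number from compound 1 to compound 3 (0.22 log units; that floor lies within the scatter), and with that floor inside the scatter, the two compounds cannot be put in order.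

Going by these compounds, whether the rise follows the loss of the hydroxyl groups or the change of ring stays open, as the step changes both at once. On these data alone, how a side chain ending in an amine or a carboxylic acid would read at this aromatic nitrogen also stays open.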